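Moving the Pyridine Nitrogen in an Antiproliferative Biaryl

The source may report more compounds than this note shows. Statements on the series, on what has been measured and on what is new or still open speak of the compounds shown alone.

Compound 1 `CCN(c1ccc(C#N)c(Cl)c1)c1cc(-c2ccncc2)ccc1C`: 1030 nM
Compound 2 `Cc1noc(C)c1-c1cccc2c1CCCN2c1ccc(C#N)c(C(F)(F)F)c1`: "not determined" (no result reported)

For the measured compounds named here, in a functional assay on CWR22R cells (Homo sapiens) for antiproliferative activity, read by CCK-8 assay, with a stated time of 6 days (a lower number here means a stronger inhibitor, a higher number a weaker inhibitor), compound 1 gives 1030 nM, the only number at hand, as compound 2 carries no reported result. Compound 3 `CCN(c1ccc(C#N)c(Cl)c1)c1cc(-c2cccnc2)ccc1C` differs from compound 1 in one place: pyridin-3-yl in place of pyridin-4-yl on an aromatic carbon. Going by the values given here, no measured pair shows what this change does, so the step in this assay is expected to stay within the usual scatter, with no clear direction. The expected step is a 1.0-fold lower number from compound 1 to compound 3 (0.01 log units; within the scatter). Compound 3 is estimated at 1000 nM, with a range from 300 nM to 3500 nM.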

Compound 3, half-maximal inhibitory concentration: 2000 nM
Beside the measured number, compound 3's estimate is 2.0-fold (0.30 log units) below it, within the range that was stated.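

In this assay, this position now has its first measured change: pyridin-3-yl in place of pyridin-4-yl gives a 1.9-fold higher number from compound 1 to compound 3 (0.29 log units; within the scatter) and so lies within the scatter. The two compounds therefore cannot be told apart here, and the ring nitrogen can occupy either of these two places without a clear change in this assay. Nothing measured explains this result. Still open, on these data alone, is whether a plain phenyl ring, a pyridin-2-yl group or an amine at this position would give a clear step.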